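Sulfonyl substituent change: compound 3 to compound 4

The source may report more compounds than this note shows. Statements on the series, on what has been measured and on what is new or still open speak of the compounds shown alone.

Measured in a functional assay on PC-3 cells (Homo sapiens) for inhibition; on this read-out higher numbers stand for weaker inhibition and lower numbers for stronger inhibition:
compound 1 `COc1cc2nc(N3CCN(S(=O)(=O)c4ccc(Cl)cc4)CC3)nc(N)c2cc1OC` gives 23000 nM
compound 2 `COc1cc2nc(N3CCN(S(=O)(=O)c4ccc(OC(F)(F)F)cc4)CC3)nc(N)c2cc1OC` gives 25000 nM
compound 3 `COc1cc2nc(N3CCN(S(=O)(=O)c4ccc(S(C)(=O)=O)cc4)CC3)nc(N)c2cc1OC` gives 17000 nM

Compound 3 has the lowest of the three numbers, yet both others sit within the scatter of it: a 1.4-fold lower number from compound 1 to compound 3 (0.13 log units; within the scatter) and a 1.5-fold lower number from compound 2 to compound 3 (0.17 log units; within the scatter), just as a 1.1-fold higher number from compound 1 to compound 2 (0.04 log units; within the scatter). Compound 4 `COc1cc2nc(N3CCN(S(=O)(=O)c4ccc5ccccc5c4)CC3)nc(N)c2cc1OC` differs from compound 3 as follows: naphthalen-2-yl in place of 4-(methylsulfonyl)phenyl on a sulfonyl sulfur. Going by the values given here, every measured step likewise exchanges the group on the sulfonyl sulfur, and none of them moved this assay beyond the scatter; no measured step, however, puts naphthalen-2-yl in place of 4-(methylsulfonyl)phenyl, so direct evidence is lacking. The expectation for compound 4 is therefore no step beyond the scatter, a 1.2-fold higher number from compound 3 to compound 4 (0.07 log units; within the scatter). Compound 4 is estimated at 20000 nM, with a range from 6000 nM to 60000 nM in this assay.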

Compound 4, half-maximal inhibitory concentration: 15000 nM
Beside the measured number, compound 4's estimate is 1.3-fold (0.12 log units) above it; the measured number falls inside the stated range.
By their numbers in this assay, from the lowest: compounds 4, 3, 1 and 2 (each within the scatter of the next).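

In this assay the new group gives a 1.1-fold lower number from compound 3 to compound 4 (0.05 log units; within the scatter) and a 1.5-fold lower number from compound 1 to compound 4 (0.19 log units; within the scatter) and a 1.7-fold lower number from compound 2 to compound 4 (0.22 log units; within the scatter). Naphthalen-2-yl brings 2 six-membered aromatic rings of carbon only and 0 hydrogen-bond acceptors to the sulfonyl sulfur, yet the number stays level with those of the three substituted phenyl groups, so a substituted phenyl is not needed there to hold this level. Nothing available accounts for this flat response.

As far as these compounds go, whether an amine or a carboxylic acid on the aromatic ring, or a change to the shared core, would move the number beyond the scatter remains open.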